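The compounds below may be only part of what the source reports. "The series", "measured", "known", "first", "only" and "open" are said of these compounds alone.

Measured compounds:
compound 1 `CCN/C(SC)=C(/C#N)C(=O)Nc1ccc(OCC)cc1` — 41600 nM
compound 2 `CCOc1ccc(NC(=O)/C(C#N)=C(\Nc2ccccc2)SC)cc1` — 49300 nM

In a functional assay on PANC-1 cells (Homo sapiens) for cytotoxicity, read by resazurin assay, with a stated time of 48 h (on this read-out higher numbers stand for weaker inhibition and lower numbers for stronger inhibition), compound 2 gives 49300 nM and compound 1 gives 41600 nM. The step of a 1.2-fold higher number from compound 1 to compound 2 (0.07 log units; within the scatter) lies within the scatter, so compound 2 is not separated from compound 1 on these numbers; both sit in the weak range.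

Compound 3 `CCOc1ccc(NC(=O)/C(C#N)=C(\NC)SC)cc1` is not yet measured. It differs from compound 2 by methyl in place of phenyl on an amine nitrogen. Within the data shown here, the only measured step that bears on this nitrogen is a 1.2-fold higher number from compound 1 to compound 2 (0.07 log units; within the scatter), phenyl in place of ethyl, which stayed within the scatter. Ethyl and phenyl on this nitrogen thus gave numbers close to each other, and methyl is not otherwise represented in the series. The expected step is therefore none beyond the scatter, a 1.1-fold lower number from compound 2 to compound 3 (0.04 log units; within the scatter). Compound 3 is estimated at 45000 nM, with a range from 20000 nM to 100000 nM.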

Compound 3, half-maximal inhibitory concentration: 26400 nM
For compound 3 the middle estimate is 1.7-fold (0.23 log units) above the measured one; measured number inside the range.
By their numbers in this assay, from the lowest: compounds 3, 1 and 2 (each within the scatter of the next).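

In this assay, methyl in place of phenyl on the amine nitrogen gives a 1.9-fold lower number from compound 2 to compound 3 (0.27 log units; within the scatter), and shortening the ethyl group to methyl gives a 1.6-fold lower number from compound 1 to compound 3 (0.20 log units; within the scatter). This position has now taken a small alkyl group of either length and an aromatic ring of six carbons, and neither change moves the number beyond the scatter, even with the loss of the whole phenyl ring in the first step. No measurement available here explains the size of either step.

On these data alone, whether a longer chain such as butyl, a benzyl group or a chain ending in a carboxylic acid on this nitrogen would separate from these three compounds remains open. The compounds shown also say nothing about changes elsewhere on the shared core.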